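The source may hold more compounds than are shown below. What is called first, only, known or untested is meant among the compounds shown, and "the series" means these compounds.

Measured in a functional assay on the whole organism (Tail, strain ICR) with Mus musculus as the target, in the tail flick test, with a stated time of 120 min, at a dose of 25 umol/kg by the oral route; on this read-out higher numbers stand for a stronger effect at the one dose given and lower numbers for a weaker effect:
compound 1 `NC(=O)CC[C@H](NC(=O)CN(c1ncnc2c1ncn2C1CCCCO1)C1CC1)C(=O)OCc1ccccc1` gives 22.3%
compound 2 `O=C(CN(c1ncnc2c1ncn2C1CCCCO1)C1CC1)N[C@@H](CCC(=O)OCc1ccccc1)C(=O)OCc1ccccc1` gives 20.7%
compound 3 `C[C@H](NC(=O)CN(c1ncnc2c1ncn2C1CCCCO1)C1CC1)C(=O)OCc1ccccc1` gives 25.3%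

Compound 3 holds the top number of the three, but neither gap to it reaches beyond the scatter: a number 3 percentage points higher from compound 1 to compound 3 (within the scatter) and a number 4.6 percentage points higher from compound 2 to compound 3 (within the scatter). The remaining comparison, a number 1.6 percentage points lower from compound 1 to compound 2 (within the scatter), is likewise within the scatter, so across all three measured compounds the substituent on this chain carbon has not moved the read-out.

Compound 4 `CC(C)C[C@H](NC(=O)CN(c1ncnc2c1ncn2C1CCCCO1)C1CC1)C(=O)OCc1ccccc1` differs from compound 3 by isopropyl in place of hydrogen on a saturated chain carbon, two bonds along the chain from an amide-type nitrogen and a carbonyl carbon. The two steps that bear on this position are the ones that strip this same chain carbon to hydrogen, both small. Accordingly no step beyond the scatter is expected in this assay: a number 0.3 percentage points lower from compound 3 to compound 4 (within the scatter). Compound 4 is therefore estimated at 25%, with a range from 12% to 38%.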

Compound 4, a percentage reported as activity, at one dose (the size of the read-out at that dose, not a potency): 12.8%
Compound 4: the middle estimate sits 12.2 percentage points above what was measured; the range from low to high includes it.
By their numbers in this assay, from the lowest: compounds 4, 2, 1 and 3 (each within the scatter of the next, the first and the last beyond it).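

In this assay, for the compounds shown here, this saturated chain carbon turns out to be sensitive to its substituent: isopropyl in place of hydrogen gives a number 12.5 percentage points lower from compound 3 to compound 4 (beyond the scatter) and is the first step beyond the scatter. Isopropyl in place of the larger groups does not separate in the same way, with a number 7.9 percentage points lower from compound 2 to compound 4 (within the scatter) and a number 9.5 percentage points lower from compound 1 to compound 4 (within the scatter) both inside it. Compounds 1 and 2 therefore remain within the scatter of both compound 3 and compound 4.

On these data alone, whether an amine, a carboxylic acid or a chain longer than isobutyl on this carbon would fall with compound 3 or compound 4 remains open. Nothing available explains the step seen with isopropyl.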